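The source may report more compounds than this note shows. Statements on the series, on what has been measured and on what is new or still open speak of the compounds shown alone.

Measured so far:
- compound 1, `Cc1ccc(-c2c(S(=O)(=O)c3ccccc3)cnc3cc(C)nn23)cc1`, gives 14% 
- compound 2, `O=S(=O)(c1ccccc1)c1cnc2cc(-c3ccc(Cl)cc3)nn2c1-c1ccc(Br)cc1`, gives 18.6% 

Both compounds were tested in a functional assay on the whole organism for inhibition, with Mus musculus as the target, with a stated time of 4 h, at a dose of 50 mg/kg by the oral route; a lower number here means less inhibition, a higher number more inhibition at the dose given (going by the name of the read-out). Compound 1 gives 14% and compound 2 gives 18.6%, so the two values lie within the scatter of each other and the two numbers are level. Both show only modest inhibition at the dose given.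

Compound 3, `Cc1cc2ncc(S(=O)(=O)c3ccccc3)c(-c3ccc(Br)cc3)n2n1`, has not yet been measured. It differs from compound 2 in one place: methyl in place of 4-chlorophenyl on an aromatic carbon. Within the data shown here, with compound 2 and compound 1 so close, there is no measured step between compounds to show how large an effect a change of this kind has, so a step of no more than the scatter is expected in this assay. The expected step is a number 3.6 percentage points lower from compound 2 to compound 3 (within the scatter), and compound 3 is estimated to give 15%, with a range from 4% to 30%.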

Compound 3, a percentage reported as inhibition, in the whole organism at one dose (the size of the read-out at that dose, not a potency): 0%
Compound 3: the middle estimate sits 15 percentage points above what was measured; the whole stated range lies above it.
By their numbers in this assay, from the lowest: compound 3; then compounds 1 and 2 (each within the scatter of the next).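

In this assay, among these compounds, replacing 4-chlorophenyl with methyl on the carbon of the five-membered aromatic ring gives a number 18.6 percentage points lower from compound 2 to compound 3 (beyond the scatter), the first step beyond the scatter at this position, so the group on this carbon can decide whether any inhibition is seen at this dose. Bromo in place of methyl on the other aromatic carbon gives a number 14 percentage points lower from compound 1 to compound 3 (beyond the scatter), so this second position can matter too, and the methyl on the five-membered ring does not keep the inhibition once bromo is present. No measurement shown here accounts for either step.

On these data alone, it remains open whether a different group on the five-membered ring, such as an amine or a longer chain, would match or exceed the inhibition of compound 2. The same question applies to a carboxylic acid in place of the bromo.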